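Hydroxypiperidine in place of morpholine: tolerance by Vero cells

This account rests on a few compounds, and the source may have more. Where it says the series, first, only, none or still open, it means among the compounds named here.

Compound 1 `Cn1nc(C(F)(F)F)cc1C(=O)Nc1ccc(S(=O)(=O)N2CCCCC2)cc1`: in an ADME assay on Vero cells (Chlorocebus sabaeus) for cytotoxicity, read by MTT assay (a higher number here means that more compound is tolerated, a lower number that less compound is tolerated), compound 1 gives > 300000 nM.
Compound 2 `Cn1nc(C(F)(F)F)cc1C(=O)Nc1ccc(S(=O)(=O)N2CCOCC2)cc1`: in this assay compound 2 gives > 300000 nM.

Both of these values are limits of the assay rather than numbers. Compound 1 and compound 2 share one core and differ only in the group on the sulfonyl sulfur. Both sit at the limit of > 300000 nM in this assay, at which 2 of the 2 values shown sit, so the step that the two limits leave unreadable from compound 1 to compound 2 gives no readable size. Compound 3 `Cn1nc(C(F)(F)F)cc1C(=O)Nc1ccc(S(=O)(=O)N2CCC(O)CC2)cc1` has not yet been measured; it differs from compound 2 in one place: 4-hydroxypiperidin-1-yl in place of morpholin-4-yl on a sulfonyl sulfur. Going by the values given here, the single measured step is unreadable, so there is no size to carry over to this new change. Since compound 2 stands at the limit, compound 3 is expected to remain at the same limit, an estimated step of a number no higher from compound 2 to compound 3 (the limit leaves the size open). The estimate for compound 3 is 300000 nM, with a range from 150000 nM to 600000 nM.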

Compound 3, half-maximal cytotoxic concentration: 274000 nM
For compound 3 the middle estimate is 1.1-fold (0.04 log units) above the measured one; measured number inside the range.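

In this assay, compound 3 is the only one of the three that gives a number rather than a limit of the assay: the limit of > 300000 nM in this assay, at which 2 of the 3 values shown sit. Placing 4-hydroxypiperidin-1-yl on the sulfonyl sulfur instead of morpholin-4-yl gives an at least 1.0-fold lower number from compound 2 to compound 3 (0.03 log units; that floor lies within the scatter), and placing hydroxy on a saturated ring carbon instead of hydrogen gives an at least 1.0-fold lower number from compound 1 to compound 3 (0.03 log units; that floor lies within the scatter). On these data alone, each of these steps starts from a limit, so its true size stays open, and neither floor shows that the change matters to the cells.

As far as these compounds go, it remains open whether a piperazin-1-yl group on the sulfonyl sulfur, or a carboxylic acid in place of the hydroxy, would be tolerated as well. From the compounds shown here alone, the true values of compound 1 and compound 2 also remain unknown.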